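The compounds below may be only part of what the source reports. "The series", "measured", "known", "first", "only" and "open" are said of these compounds alone.

Within the data shown here, in a functional assay on LOX IMVI cells (Homo sapiens) for inhibition, read by colorimetric assay and sulforhodamine B assay, with a stated time of 48 h (on this read-out lower numbers stand for stronger inhibition of growth and higher numbers for weaker inhibition of growth), compound 2 (`CCCCCCCCCCCC[C@@H](O)[C@H]1CC[C@H]([C@H](O)CCCCCCCCCCNC(=O)c2ccsc2)O1`) gives 1510 nM, the lower of the two numbers measured so far. Among the measured compounds shown here, compound 1 (`CCCCCCCCCCCC[C@@H](O)[C@H]1CC[C@H]([C@H](O)CCCCCCCCCCNC(=O)c2cncs2)O1`) gives 100000 nM, and the only measured step, a 66-fold lower number from compound 1 to compound 2 (1.82 log units; beyond the scatter), separates them. Compound 3 (`CCCCCCCCCCCC[C@@H](O)[C@H]1CC[C@H]([C@H](O)CCCCCCCCCCNC(=O)c2ccnn2C)O1`) is the next variation on compound 2: 1-methyl-1H-pyrazol-5-yl in place of thiophen-3-yl on a carbonyl carbon. For the measured compounds named here, only that single measured step bears on this change, and it was large, so the ring sitting on the carbonyl carbon evidently matters a great deal on this read-out. Compound 3 does not bring back the 1,3-thiazol-5-yl of compound 1, but it does give up the thiophen-3-yl that accompanies the lower number of compound 2. Going by the values given here, the step from compound 2 to compound 3 is therefore expected to be a 9.9-fold higher number from compound 2 to compound 3 (1.00 log units; beyond the scatter), upward toward weaker growth inhibition, though a smaller move than the one seen between compound 1 and compound 2. Compound 3 is accordingly expected to give about 15000 nM, with a range from 2500 nM to 100000 nM.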

Compound 3, concentration for 50% growth inhibition: 10 nM
For compound 3 the middle estimate is 1500-fold (3.18 log units) above the measured one, and the stated range ends above it.
By their numbers in this assay, from the lowest: compound 3; then compound 2; then compound 1.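

Compound 3 shows that this position can give far stronger growth inhibition than the two earlier compounds suggested: in this assay there is a 150-fold lower number from compound 2 to compound 3 (2.18 log units; beyond the scatter) with 1-methyl-1H-pyrazol-5-yl in place of thiophen-3-yl on a carbonyl carbon. With a 10000-fold lower number from compound 1 to compound 3 (4.00 log units; beyond the scatter) on the change from 1,3-thiazol-5-yl, the three rings now span a very wide range on the same amide, and thiophen-3-yl sits in the middle rather than at the favourable end. The entering ring differs from thiophen-3-yl in its nitrogen atoms, its methyl group and its hydrogen-bond acceptor count, but nothing available here explains the size of this change.

The compounds shown leave open whether the methyl group is needed, since a 1H-pyrazol-5-yl ring without it, or a 1-methyl-1H-pyrazol-3-yl ring, could separate the methyl group from the placement of the nitrogen atoms. As far as these compounds go, it also remains open whether a pyridin-3-yl or phenyl ring on the same carbonyl carbon would keep the low number, and whether 1-methyl-1H-pyrazol-5-yl would do so on a shorter chain.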